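Chain size: from compound 3 to compound 4

The compounds below may be only part of what the source reports. "The series", "measured", "known", "first", "only" and "open" are said of these compounds alone.

In an ADME assay on BEAS-2B cells (Homo sapiens) for cytotoxicity, read by MTT assay, with a stated time of 72 h (a higher number here means a weaker inhibitor, a lower number a stronger inhibitor), compound 3 `CCOC1OC(=O)C(Cl)=C1Cl` gives 3800 nM and compound 2 `CCCOC1OC(=O)C(Cl)=C1Cl` gives 3500 nM. Compound 1 `CCCCOC1OC(=O)C(Cl)=C1Cl` stands well apart at 22300 nM, so compound 3 sits level with compound 2 and clearly under compound 1.

Compound 4 `CC(C)(C)COC1OC(=O)C(Cl)=C1Cl` has tert-butyl in place of methyl on a saturated chain carbon bound to an oxygen on a saturated carbon.

Three chain steps bear on this change. The step of a 1.1-fold higher number from compound 2 to compound 3 (0.04 log units; within the scatter) stays within the scatter, whereas a 5.9-fold lower number from compound 1 to compound 3 (0.77 log units; beyond the scatter) and a 6.4-fold lower number from compound 1 to compound 2 (0.80 log units; beyond the scatter) are modest but beyond it. Only compound 1, at 22300 nM, shows a higher number, and it carries the largest chain measured so far. No branched chain has been measured, which leaves the extrapolation uncertain. A modest rise towards the level of compound 1 is therefore expected, reversing the direction of those two steps.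

The expected step is a 3.7-fold higher number from compound 3 to compound 4 (0.57 log units; beyond the scatter). The estimate for compound 4 is 14000 nM, with an expected range of 5000 nM to 40000 nM.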

Compound 4, half-maximal inhibitory concentration: 59000 nM
Estimate against measurement, compound 4: 4.2-fold (0.62 log units) below; the whole stated range lies below it.
By their numbers in this assay, from the lowest: compounds 2 and 3 (each within the scatter of the next); then compound 1; then compound 4.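

In this assay, tert-butyl on a saturated chain carbon bound to an oxygen on a saturated carbon goes past all three straight-chain compounds: a 16-fold higher number from compound 3 to compound 4 (1.19 log units; beyond the scatter) and a 17-fold higher number from compound 2 to compound 4 (1.23 log units; beyond the scatter) are large, and a 2.6-fold higher number from compound 1 to compound 4 (0.42 log units; beyond the scatter) is modest but still beyond the scatter. The highest number in the series therefore now belongs to the branched chain, not to the longest straight chain, and this position can move the number much further than the level pair of compound 2 and compound 3 showed. Nothing available accounts for this rise.

As far as these compounds go, whether a straight pentyl chain would reach the level of compound 4 stays open, so the contributions of branching and chain length cannot yet be separated. From the compounds shown here alone, how a chain ending in an amine or a carboxylic acid would read at this position also stays open.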